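Removing an Acetyl Group: What Compound 4 Might Show

The compounds below may be only part of what the source reports. "The series", "measured", "known", "first", "only" and "open" are said of these compounds alone.

Three compounds built on one shared core have been examined in a functional assay on MOLT-4 cells (Homo sapiens) for inhibition; a higher number here means a weaker inhibitor, a lower number a stronger inhibitor. Compound 1 `CC(=O)OC(C)n1cnc2c(Cl)nc(F)nc21` gives 41000 nM in this assay. Compound 2 `CC(=O)OC(C)n1cnc2c(S)nc(N)nc21` gives 370000 nM. Compound 3 `CC(=O)OC(C)n1cnc2c(S)nc(F)nc21` gives > 500000 nM, and this is a limit of the assay rather than a measured number. Compound 3 thus stands at the limit of > 500000 nM in this assay, at which 1 of the 3 values shown sits, the outer edge of what the assay can report.

Two single changes connect the measured compounds. The step of an at least 12-fold higher number from compound 1 to compound 3 (1.08 log units; beyond the scatter) is a large one. The step of an at least 1.3-fold higher number from compound 2 to compound 3 (0.13 log units; that floor lies within the scatter) stays within the ordinary scatter of repeated measurements.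

Compound 4 `CC(O)n1cnc2c(S)nc(F)nc21` differs from compound 3 by hydrogen in place of acetyl on an oxygen on a saturated carbon. Both measured steps concern groups on aromatic carbons of the core, while this change sits on the oxygen of the saturated side chain, so neither measured step bears directly on it. The measured steps give no reason to expect a move in either direction beyond the scatter, and the expected step of a number no higher from compound 3 to compound 4 (the limit leaves the size open) is therefore essentially flat. Compound 4 is estimated at 500000 nM, within a range from 150000 nM to 2000000 nM, with a real chance that only a limit is reported again.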

Compound 4, half-maximal inhibitory concentration: > 500000 nM
Compound 4: a limit, no number; the forecaster's own chance of this, stated with the estimate: 65%; the middle value sits exactly at the limit.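

In this assay, for the compounds shown here, compound 3 and compound 4 each give only a limit, not a number, so no step between them can be read. The compounds shown leave open whether hydroxy in place of acetoxy changes inhibition at all, and how that change would read on a compound that gives a measured number.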